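A few compounds are considered here, and "the series" means these few. Any claim that something is new, unique, unknown or untested is made for them only; others in the source may bear on it.

In a functional assay on IMR-32 cells (Homo sapiens) for cytotoxicity (a higher number here means a weaker inhibitor, a lower number a stronger inhibitor), the measured compounds stand as follows: compound 1 `COc1ccc(C2C(OC(C)=O)C(=O)N2c2cc(OC)c(OC)c(OC)c2)cc1` gives 251 nM; compound 2 `COc1ccc(C2C(O)C(=O)N2c2cc(OC)c(OC)c(OC)c2)cc1` gives 33 nM; compound 3 `COc1ccc(C2C(O)C(=O)N2c2cc(OC)c(OC)c(OC)c2)cc1[N+](=O)[O-]` gives 38 nM; 41.4 nM (2 entries).

Compound 2 has the lowest of the two single numbers. Among the measured compounds shown here, its nearest neighbour is compound 1, and the step between them, a 7.6-fold lower number from compound 1 to compound 2 (0.88 log units; beyond the scatter), is the only measured step in this set. Compound 3 has several entries, (the several entries of compound 3 in this assay, 38 nM; 41.4 nM (2 entries)), and its numbers lie within the scatter of the number for compound 2, so no order can be read between those two.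

Compound 4 `COc1cc(N2C(=O)C(O)C2c2ccc([N+](=O)[O-])o2)cc(OC)c1OC` differs from compound 2 in one place: 5-nitrofuran-2-yl in place of 4-methoxyphenyl on a saturated ring carbon. For the measured compounds named here, no measured step touches this ring exchange. The step of a 7.6-fold lower number from compound 1 to compound 2 (0.88 log units; beyond the scatter) concerns the hydroxy group on the core, which stays in place in compound 4, so it gives no guide to the size or direction of the new change. Going by the values given here, compound 3 shows only that a nitro group set on the 4-methoxyphenyl ring leaves the number roughly where compound 2 has it; exchanging the whole ring is a larger alteration, and the expectation for it is correspondingly uncertain. Compound 4 is expected to give about 120 nM in this assay, within a range from 30 nM to 600 nM. The step of a 3.6-fold higher number from compound 2 to compound 4 (0.56 log units; beyond the scatter) is expected to be a modest weakening, though a result within the scatter would not be surprising.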

Compound 4, half-maximal inhibitory concentration: > 1000 nM
Compound 4 was reported as a limit; the forecaster's own chance of this, stated with the estimate: 5%; middle value at least 8.3-fold (0.92 log units) away from the limit.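

In this assay, compound 4 gives > 1000 nM, and this is a limit of the assay rather than a single number. The step, an at least 30-fold higher number from compound 2 to compound 4 (1.48 log units; beyond the scatter), shows that the saturated ring carbon of the four-membered ring does not accept every aromatic ring equally: with the rest of the molecule unchanged, 5-nitrofuran-2-yl in place of 4-methoxyphenyl gives a much weaker compound. A nitro group alone does not go with a weak result in this small set, since compound 3 carries one on its 4-methoxyphenyl ring and gives 38 nM; 41.4 nM (2 entries).

Going by these compounds, since the value for compound 4 is a limit, the full size of the loss stays unknown, and the change from a six-membered aromatic ring of carbon only to a five-membered one cannot be separated from the presence of the nitro group on that new ring. The compounds shown do not tell how a furan-2-yl group without the nitro group, or a phenyl ring carrying an amine, would behave at this position.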